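Two Measured Analogues and an Expected Third

This account rests on a few compounds, and the source may have more. Where it says the series, first, only, none or still open, it means among the compounds named here.

Of the compounds shown here, two built on one shared core have been tested in an ADME assay on NIH3T3 cells (Mus musculus) for cytotoxicity, read by MTT assay, with a stated time of 24 h; on this read-out lower numbers stand for stronger inhibition and higher numbers for weaker inhibition. Compound 1 `O=C(CSc1nnc(-c2ccncc2)o1)N/N=C/c1ccc(O)cc1` gives 158000 nM in this assay. Compound 2 `O=C(CSc1nnc(-c2ccncc2)o1)N/N=C/c1ccccc1[N+](=O)[O-]` gives 214000 nM. The change between them, a 1.4-fold higher number from compound 1 to compound 2 (0.13 log units; within the scatter), is small. On the numbers shown, compound 2 holds the highest of the two numbers, with compound 1 as its only neighbour, and the two lie within the scatter of each other.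

Compound 3 `O=C(CSc1nnc(-c2ccncc2)o1)N/N=C/c1cc(Br)cc(Br)c1O` has not yet been measured in this assay. It differs from compound 2 in one place: 3,5-dibromo-2-hydroxyphenyl in place of 2-nitrophenyl on a carbon with a double bond to nitrogen. Among the measured compounds shown here, the only measured step on this core, from compound 1 to compound 2, stayed within the scatter. For the measured compounds named here, no measured step introduces a 3,5-dibromo-2-hydroxyphenyl, so the earlier step bears on compound 3 only indirectly: it shows that exchanging the group on the carbon with a double bond to nitrogen left the number in this assay essentially unchanged. Compound 3 is therefore expected to show no step beyond the scatter, an expected step of a 1.1-fold lower number from compound 2 to compound 3 (0.03 log units; within the scatter). The estimate for compound 3 in this assay is 200000 nM, with a range from 80000 nM to 500000 nM.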

Compound 3, half-maximal inhibitory concentration: 190000 nM
The estimate for compound 3 lay 1.1-fold (0.02 log units) above the measured number, within the range that was stated.
By their numbers in this assay, from the lowest: compounds 1, 3 and 2 (each within the scatter of the next).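

Placing 3,5-dibromo-2-hydroxyphenyl on the carbon with a double bond to nitrogen adds two more exchanges at this place in this assay, and both stay within the scatter: replacing 2-nitrophenyl gives a 1.1-fold lower number from compound 2 to compound 3 (0.05 log units; within the scatter), while replacing 4-hydroxyphenyl gives a 1.2-fold higher number from compound 1 to compound 3 (0.08 log units; within the scatter). Where the earlier compounds offered a single exchange, all three groups can now be compared with one another, and no pair among compounds 1, 2 and 3 separates beyond the scatter, even though only the entering group carries bromine. No supporting evidence is available to explain why these numbers stay together.

The compounds shown leave open whether any group at this place would produce a step beyond the scatter, since all three carry a six-membered aromatic ring of carbon only, and an amine or a carboxylic acid on that ring, or a longer alkyl chain in place of the ring, would test that directly. They also leave open whether the same flat picture would hold for changes elsewhere on the shared core.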